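This account rests on a few compounds, and the source may have more. Where it says the series, first, only, none or still open, it means among the compounds named here.

Of the compounds shown here, two carry numbers so far. Compound 1 `O=C1C(=O)N(Cc2ccccc2C(F)(F)F)c2ccc(F)cc21` in a functional assay on CHO cells for positive allosteric modulation of muscarinic acetylcholine receptor M5 (Homo sapiens), read by calcium flux (on this read-out lower numbers stand for an effect already at smaller amounts and higher numbers for an effect only at larger amounts of compound), gives 4090 nM. Compound 2 `O=C1C(=O)N(Cc2ccc(C(F)(F)F)cc2)c2ccc(OC(F)(F)F)cc21` in this assay gives 1850 nM. Compound 2 therefore stands at the lower of the two numbers, and the gap to compound 1 lies beyond the usual scatter, so of the pair compound 2 acts at the smaller amount. Going by the values given here, no two measured compounds differ in one place only, so no single step has yet been pinned down.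

The next compound, compound 3 `O=C1C(=O)N(Cc2ccc(OC(F)(F)F)cc2)c2ccc(OC(F)(F)F)cc21`, keeps the shared core of compound 2 with its trifluoromethoxy and alters one group on the other six-membered aromatic ring of carbon only: trifluoromethoxy in place of trifluoromethyl on an aromatic carbon. The place is an aromatic carbon, para to a large group. Nothing measured here separates trifluoromethyl from trifluoromethoxy at that place, so the step in this assay is expected to be small and of no fixed direction; the estimated step from compound 2 to compound 3 is a 1.1-fold higher number from compound 2 to compound 3 (0.06 log units; within the scatter), not beyond the scatter. Compound 3 is expected to give about 2100 nM, within 800 nM to 5500 nM.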

Compound 3, half-maximal effective concentration: 1860 nM
Beside the measured number, compound 3's estimate is 1.1-fold (0.05 log units) above it, within the range that was stated.
By their numbers in this assay, from the lowest: compounds 2 and 3 (each within the scatter of the next); then compound 1.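

Going by these compounds alone, this is the first step that changes one place only, and in this assay it gives a 1.0-fold higher number from compound 2 to compound 3 (0.00 log units; within the scatter) for trifluoromethoxy in place of trifluoromethyl on an aromatic carbon, para to a large group. With the rest of the structure held, this read-out therefore does not separate the two groups at this place, although the entering group brings an oxygen and a hydrogen-bond acceptor that the leaving group lacks. No measurement on hand bears on why the two groups read alike here.

As far as these compounds go, whether this place accepts other kinds of group stays open: an amine, a carboxylic acid or a longer chain there could give a step of any size or direction, and one exchange between two fluorinated groups says nothing about them. From the compounds shown here alone, it is also open whether the same exchange reads alike when the trifluoromethoxy on the shared core is replaced by another group, and compound 1 still has no single-place link to the other two compounds.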